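Chain length at the hydroxamate end: compound 2 to compound 3

This account rests on a few compounds, and the source may have more. Where it says the series, first, only, none or still open, it means among the compounds named here.

Within the data shown here, compound 2 `Nc1ncnc2c1c(-c1cnc3[nH]ccc3c1)nn2CCCCCCCCCC(=O)NO` is the only member of the series with a number in a functional assay on PLC-PRF-5 cells (Homo sapiens) for inhibition, read by MTT assay, with a stated time of 72 h; on this read-out lower numbers stand for stronger inhibition and higher numbers for weaker inhibition: compound 2 gives 34200 nM. Compound 1 `Nc1ncnc2c1c(-c1cnc3[nH]ccc3c1)nn2CCCCCCC(=O)NO` returns only a limit, > 50000 nM, which is not a number. Among the measured compounds shown here, the single measured step, an at least 1.4-fold lower number from compound 1 to compound 2 (0.16 log units; that floor lies within the scatter), moves the read-out from a limit to a weak value; its floor lies within the scatter, and the limit of > 50000 nM in this assay, at which 1 of the 2 values shown sits, is the one piece of evidence on how far the chain matters.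

Compound 3 `Nc1ncnc2c1c(-c1cnc3[nH]ccc3c1)nn2CCCCCCCCC(=O)NO` has not yet been measured. Its change from compound 2 is hydroxycarbamoyl in place of (hydroxycarbamoyl)methyl on a saturated chain carbon, eight bonds along the chain from an aromatic nitrogen. The chain is thus cut shorter, in the opposite sense to the measured step, which lengthened it and lowered the number. For the measured compounds named here, that step is the only one bearing on the change, and it gives no more than a floor, so a move toward a higher number, perhaps back to a limit, is the expectation, though it need not exceed the scatter.

Compound 3 is therefore expected to give about 45000 nM in this assay, within 20000 nM to 100000 nM, a step of a 1.3-fold higher number from compound 2 to compound 3 (0.12 log units; within the scatter).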

Compound 3, half-maximal inhibitory concentration: 14900 nM
For compound 3 the middle estimate is 3.0-fold (0.48 log units) above the measured one; the whole stated range lies above it.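

In this assay, hydroxycarbamoyl in place of (hydroxycarbamoyl)methyl, eight bonds along the chain from an aromatic nitrogen, gives a 2.3-fold lower number from compound 2 to compound 3 (0.36 log units; beyond the scatter), the first step in the series with two actual numbers and the first chain change shown to clear the scatter. With 2-(hydroxycarbamoyl)ethyl in place of hydroxycarbamoyl, six bonds along the chain from an aromatic nitrogen, the series shows an at least 3.3-fold lower number from compound 1 to compound 3 (0.52 log units; beyond the scatter), so compound 3, with the intermediate chain of the three, has the lowest number, and the read-out does not follow chain length in one direction: compound 2, with the longest chain, goes against any trend toward lower numbers with lengthening. Compound 1 remains a limit and not a number, so this last step has only a floor: the limit of > 50000 nM in this assay, at which 1 of the 3 values shown sits.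

From the compounds shown here alone, whether the chain between compound 1 and compound 3 or a longer chain than that of compound 2 would lower the number further remains open. So does whether a carboxylic acid or a primary amide at the chain end, in place of hydroxycarbamoyl, would keep the number of compound 3.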